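Chain growth on the core nitrogen: methyl to isobutyl

The source may report more compounds than this note shows. Statements on the series, on what has been measured and on what is new or still open speak of the compounds shown alone.

Three compounds of the series have numbers in an assay on HEK-293T cells for antagonist activity at vitamin D3 receptor (Homo sapiens), read by a luciferase reporter, with a stated time of 24 h; on this read-out lower numbers stand for stronger inhibition and higher numbers for weaker inhibition. Compound 1 `CC(C)c1onc(-c2c(Cl)cccc2Cl)c1COc1ccc(-c2nc3ccc(C(=O)O)cc3n2C)cc1` gives 7150 nM in this assay. Compound 3 `CCCn1c(-c2ccc(OCc3c(-c4c(Cl)cccc4Cl)noc3C(C)C)cc2)nc2ccc(C(=O)O)cc21` gives 1400 nM in this assay. Compound 2 `CCC(CC)n1c(-c2ccc(OCc3c(-c4c(Cl)cccc4Cl)noc3C(C)C)cc2F)nc2ccc(C(=O)O)cc21` reaches only the limit of this assay, > 10000 nM; this is a limit, not a number (the limit of > 10000 nM in this assay, at which 1 of the 3 values shown sits). Compound 3 therefore holds the lowest of the two numbers, with compound 1 nearest; the one single-point step shown, a 5.1-fold lower number from compound 1 to compound 3 (0.71 log units; beyond the scatter), moves the number down as the chain on the aromatic nitrogen grows from methyl to propyl.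

Compound 4 `CC(C)Cn1c(-c2ccc(OCc3c(-c4c(Cl)cccc4Cl)noc3C(C)C)cc2)nc2ccc(C(=O)O)cc21` is not yet measured. It differs from compound 3 by methyl in place of hydrogen on a saturated chain carbon bound to two saturated chain carbons, read one bond further out as propyl to isobutyl. The step from compound 1 to compound 3 is the only one that bears on it, and it concerned lengthening rather than branching; compound 2, whose chain is branched at the carbon on the nitrogen, sits at the limit. Branching further out is expected to change little, with a 1.1-fold higher number from compound 3 to compound 4 (0.06 log units; within the scatter) as the expected step. Compound 4 is therefore estimated at 1600 nM, between 500 nM and 5500 nM.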

Compound 4, half-maximal inhibitory concentration: 1180 nM
The estimate for compound 4 lay 1.4-fold (0.13 log units) above the measured number; low and high end bracket the measured number.
By their numbers in this assay, from the lowest: compounds 4 and 3 (each within the scatter of the next); then compound 1. At a limit, above all of these: compound 2.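

In this assay, a methyl added on a saturated chain carbon bound to two saturated chain carbons, reading as propyl to isobutyl, gives no difference that can be separated from the scatter (a 1.2-fold lower number from compound 3 to compound 4 (0.07 log units; within the scatter)). The branched chain keeps the advantage over the group on the nitrogen of compound 1 (a 6.1-fold lower number from compound 1 to compound 4 (0.78 log units; beyond the scatter)), so this advantage does not depend on an unbranched propyl. Across compounds 1, 3 and 4, the clear difference lies between the shortest group and the two longer chains, not between the two longer chains themselves.

On these data alone, whether a longer chain such as pentyl, or a chain ending in an amine or a hydroxyl group, would lower the number further remains open. Compound 2 also carries a fluorine and reaches only a limit, not a number, so branching at the carbon on the nitrogen cannot be read from it: the limit of > 10000 nM in this assay, at which 1 of the 4 values shown sits.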